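Replacing nitro with hydrogen: what compound 4 may show

A few compounds are considered here, and "the series" means these few. Any claim that something is new, unique, unknown or untested is made for them only; others in the source may bear on it.

Results so far in a functional assay on GC-1 cells (Mus musculus) for cytotoxicity, read by MTT assay, with a stated time of 72 h; a higher number here means a weaker inhibitor, a lower number a stronger inhibitor:
Compound 1 `Nc1nc(NC2CCCCC2)sc1C(=O)c1ccccc1` gives 9200 nM
Compound 2 `Nc1nc(NC2CCCCC2)sc1C(=O)c1cccnc1` has no reported result ("not determined" (no result reported))
Compound 3 `Nc1nc(Nc2ccc(S(N)(=O)=O)cc2)sc1C(=O)c1ccccc1[N+](=O)[O-]` gives 20000 nM

Compound 3 stands highest of the two numbers in hand (20000 nM), which makes it the weaker inhibitor, and the gap down to compound 1 lies beyond the scatter. Compound 4 `Nc1nc(Nc2ccc(S(N)(=O)=O)cc2)sc1C(=O)c1ccccc1` has not yet been measured. It is compound 3 with hydrogen in place of nitro on an aromatic carbon, so 2-nitrophenyl becomes phenyl. Going by the values given here, no measured pair isolates this change, and its size cannot be read directly from the data. Compound 1 also carries phenyl (9200 nM) but differs elsewhere, and it offers only a loose guide. In this assay the expectation is a small fall in the number that stays within the scatter. The estimate amounts to a 1.3-fold lower number from compound 3 to compound 4 (0.12 log units; within the scatter) as an expected step. For compound 4 the estimated value is 15000 nM (expected range 6000 nM to 40000 nM).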

Compound 4, half-maximal inhibitory concentration: 17000 nM
The estimate for compound 4 lay 1.1-fold (0.05 log units) below the measured number; the measured number falls inside the stated range.
By their numbers in this assay, from the lowest: compounds 1, 4 and 3 (each within the scatter of the next, the first and the last beyond it).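

Going by these compounds alone, this is the first pair that isolates a single change, and in this assay it gives a 1.2-fold lower number from compound 3 to compound 4 (0.07 log units; within the scatter). Compound 3 and compound 4 therefore cannot be told apart in this assay, so at this aromatic carbon, ortho to a large group, the nitro group and hydrogen read alike, and the nitro group, with its 3 heavy atoms, is not needed for the activity seen here. Nothing measured on these compounds offers an explanation for this result.

From the compounds shown here alone, it remains open whether an amine, a carboxylic acid or a methoxy group on the same carbon would read alike too. The compounds shown also leave open whether a nitro group on the phenyl of compound 1 would give an equally small step.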